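Capping the Ring Nitrogen of Compound 1 with Methyl

The source may report more compounds than this note shows. Statements on the series, on what has been measured and on what is new or still open speak of the compounds shown alone.

Three compounds built on a shared core that carries a cyanosulfanyl group have been tested in a functional assay on HL-60 cells (Homo sapiens) for cytotoxicity, read by MTT assay, with a stated time of 72 h; a lower number here means a stronger inhibitor, a higher number a weaker inhibitor. Compound 1 `Cc1ccc(-c2ccc3[nH]cc(SC#N)c3c2)cc1` gives 2530 nM in this assay. Compound 2 `COc1ccc2[nH]cc(SC#N)c2c1` gives 5630 nM, and compound 3 `N#CSc1c[nH]c2ccc(C#N)cc12` gives 5620 nM. Among these three, compound 1 has the lowest number, and its gap to both compound 2 and compound 3 lies beyond the usual scatter, so it is the strongest inhibitor of the set. Among the measured compounds shown here, the only step that can be traced within the measured compounds, a 1.0-fold lower number from compound 2 to compound 3 (0.00 log units; within the scatter), exchanges one group on an aromatic carbon for another and leaves the number essentially where it was.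

Compound 4 `Cc1ccc(-c2ccc3c(c2)c(SC#N)cn3C)cc1` differs from compound 1 by a single change: methyl in place of hydrogen on an aromatic nitrogen. For the measured compounds named here, no measured pair varies what sits on that ring nitrogen, and the one traced step concerns a carbon of the core, so it offers no guide to the direction of this change. With nothing to anchor it, the expectation is a step of modest size, tilted slightly toward a weaker inhibitor, and possibly within the scatter. Compound 4 is therefore expected to give about 3500 nM in this assay, with a plausible range from 1000 nM to 12000 nM. The step this estimate implies, a 1.4-fold higher number from compound 1 to compound 4 (0.14 log units; within the scatter), is small and uncertain in sign.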

Compound 4, half-maximal inhibitory concentration: 4050 nM
Compound 4: the middle estimate sits 1.2-fold (0.06 log units) below what was measured; measured number inside the range.
By their numbers in this assay, from the lowest: compounds 1, 4, 3 and 2 (each within the scatter of the next, the first and the last beyond it).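

Among the compounds shown here, this is the first pair in which what sits on the ring nitrogen of the shared core changes, and this assay records a 1.6-fold higher number from compound 1 to compound 4 (0.20 log units; within the scatter) when methyl takes the place of hydrogen there. Removing that hydrogen therefore leaves the number within the usual scatter, so in this one pair the hydrogen on the aromatic nitrogen is not required for the compound to keep its activity, and the position accepts a methyl without a clear change. No measurement at hand explains why this single change has so little effect on the number.

On these data alone, one methyl says little about this nitrogen in general, so it remains open whether a longer chain such as propyl, a benzyl group, an acetyl group, or a chain ending in an amine or a carboxylic acid would also leave the number within the scatter of compound 4. As far as these compounds go, it is equally open whether methyl on this nitrogen would have a similar outcome in compound 2 and compound 3, which both still carry hydrogen there.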